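Cytotoxicity notes on the biaryl amide series

The compounds below may be only part of what the source reports. "The series", "measured", "known", "first", "only" and "open" are said of these compounds alone.

Measured so far in an ADME assay on BJ cells (Homo sapiens) for cytotoxicity, read by CellTiter-Glo and resazurin assay, with a stated time of 72 h; on this read-out lower numbers stand for an effect already at smaller amounts and higher numbers for an effect only at larger amounts of compound:
Compound 1 `CCOC(=O)CCCCCOc1cccc(CN(C(=O)c2ccc(-c3ccc4ccccc4c3)cc2)C(C)C)c1`: in this assay compound 1 gives > 26000 nM, a limit of the assay and not a number.
Compound 2 `CCOC(=O)CCCCCOc1cccc(CN(C(=O)c2ccc(-c3cccc(-c4ccccc4)c3)cc2)C(C)C)c1`: in this assay compound 2 gives > 26000 nM, again a limit.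
Compound 3 `CCOC(=O)CCCCCOc1cccc(CN(C(=O)c2ccc(-c3cccc(OCC(C)C)c3)cc2)C(C)C)c1`: in this assay compound 3 gives > 26000 nM, also a limit.

Compound 3 therefore stands at the limit, as do the other two values shown (the limit of > 26000 nM in this assay, at which 3 of the 3 values shown sit). The steps among the measured compounds, a step that the two limits leave unreadable from compound 1 to compound 2, a step that the two limits leave unreadable from compound 1 to compound 3 and a step that the two limits leave unreadable from compound 2 to compound 3, are all unreadable, so none of them gives a size to carry forward.

Compound 4 `CCOC(=O)CCCCCOc1cccc(CN(C(=O)c2ccc(-c3cccc(OC(C)C)c3)cc2)C(C)C)c1` differs from compound 3 by one change: isopropyl in place of isobutyl on an oxygen on an aromatic ring. For the measured compounds named here, no measured step bears on this change with a readable size; what the three values show is only that changes on the aromatic carbon of the shared core have left every compound at the limit. For compound 4 the expectation is therefore no step beyond the scatter, a step that the limit leaves unreadable from compound 3 to compound 4, with the result most likely reported again as a limit. Compound 4 is estimated at 40000 nM, within 26000 nM to 100000 nM.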

Compound 4, half-maximal effective concentration: > 26000 nM
Compound 4: only a limit was reported; the forecaster's own chance of this, stated with the estimate: 85%; the middle value does not contradict the limit.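

Compound 4 also sits at a limit of the assay, so its steps from compound 1, compound 2 and compound 3 cannot be read and give no new size: the limit of > 26000 nM in this assay, at which 4 of the 4 values shown sit.

The compounds shown leave open where any of them reaches a half-maximal effect in this assay and whether these changes shift that concentration.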